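Diethylamino in place of butyl on a pyridine-carboxamide series

The compounds below may be only part of what the source reports. "The series", "measured", "known", "first", "only" and "open" are said of these compounds alone.

Measured compounds:
Compound 1, `CCCOc1cc(C(=O)Nc2nn[nH]n2)nc(-c2ccc(N)cc2)c1`: 7%
Compound 2, `CCCCc1ccc(-c2cc(C)cc(C(=O)Nc3nn[nH]n3)n2)cc1`: 17%

In a functional assay on the whole organism for inhibition, with Rattus norvegicus as the target, at a dose of 0.3 mg/kg by the oral route (on this read-out lower numbers stand for a weaker effect and higher numbers for a stronger effect at the one dose given), compound 1 gives 7%. In this assay compound 2 gives 17%, the higher of the two numbers, though the gap to compound 1 lies within the usual scatter, so the two cannot be ranked against each other on this evidence. For the measured compounds named here, no step between measured compounds that differ in one place is available, so nothing is known about how single changes move the read-out here.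

Compound 3, `CCN(CC)c1ccc(-c2cc(C)cc(C(=O)Nc3nn[nH]n3)n2)cc1`, is not yet measured. It differs from compound 2 as follows: diethylamino in place of butyl on an aromatic carbon. With both measured values low and close to each other, the step expected a number 2 percentage points lower from compound 2 to compound 3 (within the scatter) is small, in no clear direction, and not beyond the scatter. Compound 3 is therefore estimated at 15%, within a range of 3% to 35%.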

Compound 3, a percentage reported as inhibition, in the whole organism at one dose (the size of the read-out at that dose, not a potency): 19%
Compound 3: the middle estimate sits 4 percentage points below what was measured; the measured number falls inside the stated range.
By their numbers in this assay, from the lowest: compounds 1, 2 and 3 (each within the scatter of the next, the first and the last beyond it).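

In this assay, for the compounds shown here, replacing butyl with diethylamino on this aromatic carbon, para to a large group, provides the first comparison in which only one place differs, and the step is a number 2 percentage points higher from compound 2 to compound 3 (within the scatter). At this position, therefore, a chain of carbon only and a group that brings in a nitrogen and a hydrogen-bond acceptor cannot be told apart on this read-out at the one dose given. No measurement shown offers an explanation for this result.

Going by these compounds, it remains open whether a morpholine ring, a carboxylic acid or a hydrogen atom at the same place would give a number beyond the scatter of compound 2 and compound 3. Since each compound is shown at a single dose, their potencies also remain unknown.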